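From compound 3 to compound 4: a larger chain

A few compounds are considered here, and "the series" means these few. Any claim that something is new, unique, unknown or untested is made for them only; others in the source may bear on it.

In a functional assay on SW480 cells (Homo sapiens) for inhibition (on this read-out higher numbers stand for weaker inhibition and lower numbers for stronger inhibition), compound 1 (`COc1cc[nH]c1/C=C1\C(=O)Nc2ccc(F)c(C#C[C@@H](C)O)c21`) gives 130 nM and compound 2 (`COc1cc[nH]c1/C=C1\C(=O)Nc2ccc(F)c(C#CC(O)CN)c21`) gives 110 nM while compound 3 (`CN[C@@H](C#Cc1c(F)ccc2c1/C(=C/c1[nH]ccc1OC)C(=O)N2)CO`) gives 80 nM on the same read-out. These three numbers lie within the scatter of each other, so compound 3 cannot be separated from the other two.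

Compound 4 (`COc1cc[nH]c1/C=C1\C(=O)Nc2ccc(F)c(C#C[C@@H](NS(C)(=O)=O)[C@@H](C)O)c21`) has 2-hydroxy-1-(methanesulfonamido)propyl in place of 2-hydroxy-1-(methylamino)ethyl on a triple-bonded carbon and shares the core of compound 3.

Three measured steps at this same place bear on the change, and each lies within the scatter. There is a 1.2-fold lower number from compound 1 to compound 2 (0.07 log units; within the scatter) with 2-amino-1-hydroxyethyl in place of 1-hydroxyethyl, then a 1.6-fold lower number from compound 1 to compound 3 (0.21 log units; within the scatter) with 2-hydroxy-1-(methylamino)ethyl in place of 1-hydroxyethyl, and finally a 1.4-fold lower number from compound 2 to compound 3 (0.14 log units; within the scatter) on exchanging those two groups. Going by the values given here, none of the measured compounds carries a methanesulfonamido group, so these steps are only a loose guide and the range must stay wide.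

Starting from compound 3 at 80 nM and with steps this small at the same place, no step beyond the scatter is expected in this assay for the new chain. The expected step is a 1.5-fold higher number from compound 3 to compound 4 (0.18 log units; within the scatter) in all. Compound 4 is estimated at 120 nM with an expected range of 40 nM to 400 nM around that figure.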

Compound 4, half-maximal inhibitory concentration: 1190 nM
Compound 4: the middle estimate sits 9.9-fold (1.00 log units) below what was measured; measured number outside the range, above it.
By their numbers in this assay, from the lowest: compounds 3, 2 and 1 (each within the scatter of the next); then compound 4.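

In this assay this place on a triple-bonded carbon, which had shown no step beyond the scatter among compounds 1, 2 and 3, now gives a 15-fold higher number from compound 3 to compound 4 (1.17 log units; beyond the scatter) and also an 11-fold higher number from compound 2 to compound 4 (1.03 log units; beyond the scatter) and a 9.2-fold higher number from compound 1 to compound 4 (0.96 log units; beyond the scatter), all three beyond the scatter. The position is therefore not indifferent to the chain it carries: the three smaller chains sit together, while the 2-hydroxy-1-(methanesulfonamido)propyl chain of 9 heavy atoms stands apart from all of them. This single change brings in the methanesulfonamido group, a longer propyl chain and a second defined stereocentre together, and nothing at hand accounts for the step.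

The compounds shown leave open which of these parts goes with the higher number, and a 2-hydroxy-1-(methanesulfonamido)ethyl chain or a 2-hydroxy-1-(methylamino)propyl chain would separate the first two. They also leave open whether an acetamido group on the same chain would behave like the methanesulfonamido group, and what the opposite configuration at either stereocentre would give.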